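The source may report more compounds than this note shows. Statements on the series, on what has been measured and on what is new or still open speak of the compounds shown alone.

Measured compounds in an assay on isolated protein for inhibition of cathepsin S (Homo sapiens); a higher number here means a weaker inhibitor, a lower number a stronger inhibitor:
compound 1 `O=C(N[C@@H](CO)CN1CCc2cc(F)ccc21)O[C@@H](CC1CCCCC1)C(=O)N1CCOCC1`, compound 1 gives 143 nM
compound 2 `C[C@@H](CNc1ccc(OC(F)(F)F)cc1)NC(=O)O[C@@H](Cc1ccccc1)C(=O)N1CCOCC1`, compound 2 gives 12600 nM
compound 3 `COCCN(C)C(=O)[C@H](CC1CCCCC1)OC(=O)N[C@@H](C)CN1CC(C)(C)c2cc(F)ccc21`, compound 3 gives 172 nM

Compound 3 stands second highest of the three numbers. Its nearest neighbour is compound 1, whose number is lower by an amount within the scatter, so the two cannot be ordered; compound 2 lies far higher, beyond the scatter.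

Compound 4 `C[C@@H](CN1CC(C)(C)c2cc(F)ccc21)NC(=O)O[C@@H](CC1CCCCC1)C(=O)N1CCN(S(C)(=O)=O)CC1` is not yet measured in this assay. It follows from compound 3 by one change: 4-(methylsulfonyl)piperazin-1-yl in place of (2-methoxyethyl)(methyl)amino on a carbonyl carbon. Among the measured compounds shown here, no measured pair here isolates this kind of change, so no step size is known for it. The expectation is a step from compound 3 to compound 4 of a 1.3-fold lower number from compound 3 to compound 4 (0.12 log units; within the scatter), that is, none beyond the scatter in either direction. Compound 4 is estimated at 130 nM, within a range of 40 nM to 420 nM.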

Compound 4, inhibition constant: 1080 nM
The estimate for compound 4 lay 8.3-fold (0.92 log units) below the measured number, and the stated range ends below it.
By their numbers in this assay, from the lowest: compounds 1 and 3 (each within the scatter of the next); then compound 4; then compound 2.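

Replacing (2-methoxyethyl)(methyl)amino with 4-(methylsulfonyl)piperazin-1-yl on the carbonyl carbon gives a 6.3-fold higher number from compound 3 to compound 4 (0.80 log units; beyond the scatter) in this assay, the first step read at this position. The group on this carbonyl carbon therefore moves the number, and this larger ring-bearing group is the less favourable of the two compared. No measurement shown offers an explanation for this step. The compounds shown leave open whether the step follows the piperazine ring or the methylsulfonyl group on it. A piperazine bearing an acetyl group, or the same ring with a free secondary amine, would separate the two.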